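Trading a Methyl for Hydrogen on an Aromatic Oxygen

A few compounds are considered here, and "the series" means these few. Any claim that something is new, unique, unknown or untested is made for them only; others in the source may bear on it.

Of the compounds shown here, three with a shared core have been tested in a functional assay on SR cells (Homo sapiens) for inhibition; on this read-out lower numbers stand for stronger inhibition of growth and higher numbers for weaker inhibition of growth. Compound 1 `COc1cc(/C=C/c2ccc(S(N)(=O)=O)cc2)cc(OC)c1` gives 19700 nM. Compound 2 `COc1cccc(/C=C/c2ccc(S(N)(=O)=O)cc2)c1` gives 5210 nM, and compound 3 `NS(=O)(=O)c1ccc(/C=C/c2ccc(O)cc2)cc1` gives 4680 nM. Among these three numbers compound 2 stands second highest: its nearest neighbour is compound 3, whose value lies within the scatter of it, while compound 1 is the furthest away, beyond the scatter. Among the compounds with values here, the only measured step is a 3.8-fold lower number from compound 1 to compound 2 (0.58 log units; beyond the scatter), which puts hydrogen in place of the whole methoxy group.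

Compound 4 `NS(=O)(=O)c1ccc(/C=C/c2cccc(O)c2)cc1` has not yet been measured. It differs from compound 2 by hydrogen in place of methyl on an oxygen on an aromatic ring. Within the data shown here, no measured step makes exactly this change. The step from compound 1 to compound 2 removes methoxy outright and was modest, while compound 3, which carries a hydroxy group, differs from compound 2 in more than one place, so their two values can only be set side by side, and they lie within the scatter. The expected step is therefore a 1.2-fold lower number from compound 2 to compound 4 (0.06 log units; within the scatter), meaning no movement beyond the scatter. Compound 4 is expected to give 4500 nM, with a likely range from 1500 nM to 13000 nM.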

Compound 4, concentration for 50% growth inhibition: 17800 nM
For compound 4 the middle estimate is 4.0-fold (0.60 log units) below the measured one; the measured number lies above the stated range.
By their numbers in this assay, from the lowest: compounds 3 and 2 (each within the scatter of the next); then compounds 4 and 1 (each within the scatter of the next).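

Read directly in this assay, the exchange gives a 3.4-fold higher number from compound 2 to compound 4 (0.53 log units; beyond the scatter) and so is not a silent change on the shared core. Its direction is opposite to that of a 3.8-fold lower number from compound 1 to compound 2 (0.58 log units; beyond the scatter), a step in which a whole methoxy group leaves, so on these compounds removing the entire group and removing only its methyl do not act alike. Here, replacing methoxy with hydroxy brings weaker inhibition of growth, a drop that the comparison of compound 2 with compound 3 could not have revealed.

The compounds shown offer no measurement that explains this step. On these data alone, it remains open whether an ethoxy group or an amine on this aromatic carbon would behave more like methoxy or more like hydroxy.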